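The compounds below may be only part of what the source reports. "The series", "measured", "known", "first", "only" and "open" are said of these compounds alone.

Compound 2 `CCOC(=O)c1c(-c2ccc(OC)cc2F)csc1N` is tested in an assay on isolated protein for inhibition of protein kinase C zeta type (Homo sapiens), with stated times of 1 h and 2.5 min, tested at 30 uM (on this read-out lower numbers stand for less inhibition and higher numbers for more inhibition at the one concentration tested (going by the name of the read-out)), where compound 2 gives 100%. Its closest measured neighbour, compound 1 `CCOC(=O)c1c(-c2ccc(OC)cc2)csc1N`, gives 100% in this assay, and the step of no change at the digits printed from compound 1 to compound 2 (within the scatter) shows fluoro in place of hydrogen on an aromatic carbon staying within the scatter. Compound 3 `CCOC(=O)c1c(-c2ccccc2F)csc1N` follows from compound 2 by a different change, (hydrogen in place of methoxy on an aromatic carbon). Going by the values given here, no measured step removes a methoxy, so the only guide is that both measured compounds sit at the top of the scale. The step of a number 10 percentage points lower from compound 2 to compound 3 (within the scatter) is therefore expected to be small. Compound 3 is estimated at 90%, between 60% and 100%.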

Compound 3, a percentage reported as inhibition, at one concentration (the size of the read-out at that concentration, not a potency): 62%
Estimate against measurement, compound 3: 28 percentage points above, within the range that was stated.
By their numbers in this assay, from the lowest: compound 3; then compounds 1 and 2 (each within the scatter of the next).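

In this assay, removing the methoxy costs clearly more than the usual scatter, a number 38 percentage points lower from compound 2 to compound 3 (beyond the scatter), whereas the fluoro change, no change at the digits printed from compound 1 to compound 2 (within the scatter), moved nothing. This place on the aromatic ring, para to a large group, is therefore one where a change shows in the read-out. Nothing measured here gives a reason for the drop.

Still open, as far as these compounds go, is whether a hydroxy, an ethoxy or an amine at this place would keep the level of compound 2 at 100%. Going by these compounds alone, the loss is also seen only with the fluoro present, so the same step without it remains unknown.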